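The compounds below may be only part of what the source reports. "The series", "measured", "known", "first", "only" and "open" are said of these compounds alone.

Measured compounds in an assay on HEK293 cells for displacement of a labelled ligand from 5-hydroxytryptamine receptor 6 (Homo sapiens), read by radioligand binding, with a stated time of 60 min, tested at 100 nM; a higher number here means more inhibition at the concentration tested (going by the name of the read-out), a lower number less inhibition:

- compound 1, `CN(c1ccccc1)S(=O)(=O)c1ccc2c(c1)sc(=O)n2CCN1CCCCC1`, gives 0%
- compound 2, `CN(c1cccc2ccccc12)S(=O)(=O)c1ccc2c(c1)sc(=O)n2CCN1CCCCC1`, gives 14%
- compound 3, `O=c1sc2cc(S(=O)(=O)Nc3ccccc3)ccc2n1CCN1CCCC1`, gives 37%

Compound 1 and compound 2 share one core and differ in a single spot: naphthalen-1-yl in place of phenyl on a sulfonamide nitrogen. That exchange produced a number 14 percentage points higher from compound 1 to compound 2 (beyond the scatter). Compound 3 has a different core; the difference between its core and that of compound 1 is not broken down here. Of the three measured compounds, compound 3 stands highest in this assay, with its step to compound 2 and its step to compound 1 both beyond the usual scatter.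

Compound 4, `O=c1sc2cc(S(=O)(=O)Nc3cccc4ccccc34)ccc2n1CCN1CCCC1`, has not been measured. It is related to compound 3 by the same kind of change that relates compound 2 to compound 1: naphthalen-1-yl in place of phenyl on a sulfonamide nitrogen. The surroundings are not identical, however. For the measured compounds named here, in compound 1 the sulfonamide nitrogen carrying the aryl group has a saturated chain carbon and a sulfonyl sulfur as its other neighbours, whereas in compound 3 its only other neighbour is the sulfonyl sulfur. So the change is the same kind of change, not the same one.

Going by the values given here, with only one measured example of this exchange, the expectation for compound 4 rests on compound 3 giving 37% and on the modest rise seen in a number 14 percentage points higher from compound 1 to compound 2 (beyond the scatter). A step of similar size is expected from compound 3 to compound 4, namely a number 13 percentage points higher from compound 3 to compound 4 (beyond the scatter). Compound 4 is therefore estimated at 50% in this assay, most likely between 30% and 70%.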

Compound 4, a percentage reported as inhibition, at one concentration (the size of the read-out at that concentration, not a potency): 0%
For compound 4 the middle estimate is 50 percentage points above the measured one; measured number outside the range, below it.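

In this assay, for the compounds shown here, exchanging the phenyl group for naphthalen-1-yl, on a core whose sulfonamide nitrogen has the sulfonyl sulfur as its only other neighbour, gave a number 37 percentage points lower from compound 3 to compound 4 (beyond the scatter). Going by these compounds alone, the exchange therefore did not carry over from one core to the other, and its effect differed in direction as well as in size: the same change on two cores in this assay, a number 14 percentage points higher (beyond the scatter) from compound 1 to compound 2 and a number 37 percentage points lower (beyond the scatter) from compound 3 to compound 4, 51 percentage points apart, beyond the scatter of two such steps This shows that the earlier step could not be transferred to the second core, but it does not show which feature of the cores is responsible, since they differ in more than one place, including the neighbours of the sulfonamide nitrogen, and each core supplies only a single pair of compounds read at one concentration, which gives no potency.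

The compounds shown leave open whether the reversal follows from the different neighbours of the sulfonamide nitrogen or from another difference in the cores, which a pair of cores differing in that one place alone could separate. They also leave open how other groups on that nitrogen would behave on either core, such as naphthalen-2-yl or benzyl, so nothing yet indicates whether the result is particular to naphthalen-1-yl.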